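Methyl in place of fluoro: expected tolerance of compound 4

The compounds below may be only part of what the source reports. "The series", "measured", "known", "first", "only" and "open" are said of these compounds alone.

Compound 3 `COC(=O)c1cc(F)ccc1OC(=O)COc1cc(O)c2c(=O)cc(-c3ccccc3)oc2c1` gives 389000 nM in an ADME assay on cells (T-cell, Mus musculus, strain BALB/c) for cytotoxicity, read by MTT assay, with a stated time of 48 h (a lower number here means that less compound is tolerated, a higher number that more compound is tolerated), the highest of the two plain numbers shown. Compound 2 `COC(=O)c1ccc(C)cc1OC(=O)COc1cc(O)c2c(=O)cc(-c3ccccc3)oc2c1` gives 250000 nM, and a 1.6-fold higher number from compound 2 to compound 3 (0.19 log units; within the scatter). Compound 1 `COC(=O)c1cc(Cl)ccc1OC(=O)COc1cc(O)c2c(=O)cc(-c3ccccc3)oc2c1` reaches only a limit of this assay, > 436000 nM. Compound 4 `COC(=O)c1cc(C)ccc1OC(=O)COc1cc(O)c2c(=O)cc(-c3ccccc3)oc2c1` carries methyl in place of fluoro on an aromatic carbon. The measured steps that bear on this change are all small: an at least 1.7-fold lower number from compound 1 to compound 2 (0.24 log units; that floor lies within the scatter), an at least 1.1-fold lower number from compound 1 to compound 3 (0.04 log units; that floor lies within the scatter), and the exchange of one substituted group for another gave a 1.6-fold higher number from compound 2 to compound 3 (0.19 log units; within the scatter). None of these steps moves beyond the scatter, so no real shift is expected here either. Compound 4 is therefore estimated at 300000 nM, with a range from 160000 nM to 450000 nM, which would mean a 1.3-fold lower number from compound 3 to compound 4 (0.11 log units; within the scatter) as the expected step.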

Compound 4, half-maximal cytotoxic concentration: 306000 nM
Compound 4: the middle estimate sits 1.0-fold (0.01 log units) below what was measured; the range from low to high includes it.
By their numbers in this assay, from the lowest: compounds 2, 4 and 3 (each within the scatter of the next). At a limit, above all of these: compound 1.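

In this assay, methyl in place of fluoro at this position gives a 1.3-fold lower number from compound 3 to compound 4 (0.10 log units; within the scatter) and so adds no real shift on this aromatic carbon. The two methyl compounds, which differ only in where the methyl sits on that ring, show a 1.2-fold higher number from compound 2 to compound 4 (0.09 log units; within the scatter) as their step. Methyl in place of chloro gives an at least 1.4-fold lower number from compound 1 to compound 4 (0.15 log units; that floor lies within the scatter) as a floor only, since compound 1 stands at a limit: the limit of > 436000 nM in this assay, at which 1 of the 4 values shown sits.

Only fluoro, chloro and methyl are shown at this position. Going by these compounds, whether an amine, a carboxylic acid or a longer chain there would move the number beyond the scatter remains open.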